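The source may report more compounds than this note shows. Statements on the series, on what has been measured and on what is new or still open speak of the compounds shown alone.

Compound 1 `CC#CCOC(=O)/C=C(C)/C=C/CC(C)CCCC(C)C`: 6.4
Compound 2 `CCOC(=O)/C=C(C)/C=C/CC(C)CCC(OC)C(C)(C)OC`: 4.34

Both compounds were measured in a physicochemical assay for lipophilicity; on this read-out higher numbers stand for higher lipophilicity and lower numbers for lower lipophilicity. Of these two numbers, compound 1 holds the higher one; compound 2 sits a long way lower, a gap well beyond the usual scatter of this assay. Compound 3 `CC(/C=C/CC(C)CCCC(C)C)=C\C(=O)NCC(C)C` has not yet been measured. It differs from compound 1 in a single place: isobutylamino in place of (but-2-yn-1-yl)oxy on a carbonyl carbon. For the measured compounds named here, no measured pair shows this same change, so nothing in the data fixes the size of the step directly, and what follows is an expectation only. A step of a number 1.10 log units lower from compound 1 to compound 3 (beyond the scatter) is expected in this assay, downward and beyond the scatter. Because compound 1 gives 6.4, compound 3 is expected to come out near 5.3, with a range from 4.6 to 6.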

Compound 3, partition coefficient: 6.19
For compound 3 the middle estimate is 0.89 log units below the measured one; measured number outside the range, above it.
By their numbers in this assay, from the lowest: compound 2; then compounds 3 and 1 (each within the scatter of the next).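

For the compounds shown here, compound 1 and compound 3 are the first pair here that differs in one place, and in this assay the change to isobutylamino on a carbonyl carbon gives a number 0.21 log units lower from compound 1 to compound 3 (within the scatter) and so leaves the read-out unresolved from that of (but-2-yn-1-yl)oxy. On this carbonyl carbon, a group with a triple bond and a hydrogen-bond acceptor can therefore give way to one with a hydrogen-bond donor and no acceptor, with no change beyond the scatter. Nothing measured here gives a reason for this result.

This single pair cannot say whether the same swap would behave alike on another core, such as that of compound 2. Also open, going by these compounds, is how a carboxylic acid, or a longer chain on the amide nitrogen, would read at this place.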